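A Third Aryl Group on a Weak Series

The compounds below may be only part of what the source reports. "The series", "measured", "known", "first", "only" and "open" are said of these compounds alone.

Compound 1: `COc1ccc(C(F)(F)F)cc1Nc1ncc(C(F)(F)F)c(N2Cc3cccc(N(C)S(C)(=O)=O)c3C2)n1`, giving > 20000 nM.
Compound 2: `Cc1cc(C)cc(Nc2ncc(C(F)(F)F)c(N3Cc4cccc(N(C)S(C)(=O)=O)c4C3)n2)c1`, giving > 20000 nM.

In an assay on Sf9 cells for inhibition of tyrosine-protein kinase receptor UFO (Homo sapiens), read by luminescence and ADP-Glo (a higher number here means a weaker inhibitor, a lower number a stronger inhibitor), compound 1 gives only a limit of the method, > 20000 nM. Compound 2 likewise gives only a limit, > 20000 nM. The step that the two limits leave unreadable from compound 1 to compound 2 therefore has no readable size, as shown by the limit of > 20000 nM in this assay, at which 2 of the 2 values shown sit. Compound 2 thus stands at the edge of what this assay can report, with no number of its own.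

Compound 3 is `Cc1cc(Cl)ccc1Nc1ncc(C(F)(F)F)c(N2Cc3cccc(N(C)S(C)(=O)=O)c3C2)n1`. It differs from compound 2 by 4-chloro-2-methylphenyl in place of 3,5-dimethylphenyl on a nitrogen on an aromatic ring. Among the compounds with values here, the only measured step, a step that the two limits leave unreadable from compound 1 to compound 2, sits entirely at the limit and so gives no guidance on direction or size. No step beyond the usual scatter is expected, so for compound 3 the expected step is a step that the limit leaves unreadable from compound 2 to compound 3. Compound 3 is therefore estimated at 30000 nM, with a range from 10000 nM to 100000 nM, most likely again reported as a limit.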

Compound 3, half-maximal inhibitory concentration: > 20000 nM
Compound 3 ended at the assay's limit; the forecaster's own chance of this, stated with the estimate: 80%; the middle value is on the limit's open side.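

In this assay compound 3 also gives only a limit, > 20000 nM. The steps among compound 1, compound 2 and compound 3 therefore cannot be read: the limit of > 20000 nM in this assay, at which 3 of the 3 values shown sit.

The compounds shown leave open whether any group at this place on the shared core would give a real number in this assay.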